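Replacing cyclohexyl with isopropyl in compound 3

The source may hold more compounds than are shown below. What is called first, only, known or untested is meant among the compounds shown, and "the series" means these compounds.

Of the compounds shown here, three have been measured in a functional assay on MDA-MB-231 cells (Homo sapiens) for antiproliferative activity, read by sulforhodamine B assay; on this read-out higher numbers stand for weaker inhibition of growth and lower numbers for stronger inhibition of growth. Compound 1 (`COc1cccc(OCCC(C)(C)C)c1C(=O)/C=C/c1ccc(O)cc1`) gives > 30000 nM, which is a limit and not a number. Compound 2 (`CC(C)(C)CCOc1cccc(O)c1C(=O)/C=C/c1ccc(C(=O)O)cc1`) gives 11200 nM. Compound 3 (`O=C(/C=C/c1ccc(O)cc1)c1c(O)cccc1OCCC1CCCCC1`) gives > 30000 nM, also a limit and not a number. Compound 3 therefore stands at the limit of > 30000 nM in this assay, at which 2 of the 3 values shown sit.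

Compound 4 (`CC(C)CCOc1cccc(O)c1C(=O)/C=C/c1ccc(O)cc1`) carries isopropyl in place of the cyclohexyl of compound 3, on a saturated chain carbon, two bonds along the chain from an oxygen on an aromatic ring: isopropyl in place of cyclohexyl on a saturated chain carbon, two bonds along the chain from an oxygen on an aromatic ring. With compound 3 giving > 30000 nM, a limit, no step beyond the scatter is expected in this assay. The expected change is an at least 1.0-fold lower number from compound 3 to compound 4 (0.02 log units; that floor lies within the scatter). For compound 4 the estimated value is 28000 nM, with an expected range of 12000 nM to 60000 nM.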

Compound 4, concentration for 50% growth inhibition: 10300 nM
Beside the measured number, compound 4's estimate is 2.7-fold (0.43 log units) above it, and the stated range ends above it.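

In this assay, within the data shown here, isopropyl in place of cyclohexyl gives an at least 2.9-fold lower number from compound 3 to compound 4 (0.46 log units; beyond the scatter) and so the first step that can be read at this position. The end of this chain is thus a place where the read-out responds, and the smaller of the two groups gives the stronger inhibition of growth. Compound 3 holds a limit and not a number, so the step is only a floor: the limit of > 30000 nM in this assay, at which 2 of the 4 values shown sit.

The compounds shown leave open whether an amine, a carboxylic acid or a longer chain at the same place would move the number further. They also leave open whether cyclopropyl would match compound 4.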